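The source may hold more compounds than are shown below. What is called first, only, known or untested is meant among the compounds shown, and "the series" means these compounds.

Measured so far in an ADME assay on microsomes from liver (Mus musculus) for metabolic stability, read by LC-MS, with a stated time of 1 h, tested at 5 uM; on this read-out lower numbers stand for a less stable compound and higher numbers for a more stable compound:

Compound 1 `COc1cc(OC)cc(N2CCN(C(=O)c3oc(C)nc3-c3cccc(F)c3)CC2)c1` gives 11.6%.
Compound 2 `Cc1nc(-c2ccccc2)c(C(=O)N2CCN(c3cccc(C)c3C)CC2)o1` gives 83.6%.
Compound 3 `Cc1nc(-c2ccc(F)cc2)c(C(=O)N2CCN(c3cc(Cl)cc(Cl)c3)CC2)o1` gives 31.1%.

Compound 2 stands highest of the three numbers. Its nearest neighbour is compound 3, whose value lies well below it, beyond the scatter, and compound 1 lies lower still, also beyond the scatter. No pair among these three differs in only one place, so no single-point step is available to lean on.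

Compound 4 `Cc1ccc(C)c(N2CCN(C(=O)c3oc(C)nc3-c3ccccc3)CC2)c1` is the next candidate for this assay. It differs from compound 2 as follows: 2,5-dimethylphenyl in place of 2,3-dimethylphenyl on an amine nitrogen in a ring. The two have the same atoms, joined differently: a 2,3-dimethylphenyl leaves and a 2,5-dimethylphenyl enters, on an amine nitrogen in a ring of a six-membered non-aromatic ring with two nitrogens.

With no measured step of this kind in the series, the expectation rests on compound 2 alone. A modest step downward, or none beyond the scatter, is expected in this assay; the expected step is a number 13.6 percentage points lower from compound 2 to compound 4 (beyond the scatter). Compound 4 is estimated at 70%, within a range from 45% to 92%.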

Compound 4, percent of the compound remaining: 1.4%
Compound 4: middle estimate off by 68.6 percentage points, on the high side; the measured number lies below the stated range.
By their numbers in this assay, from the lowest: compound 4; then compound 1; then compound 3; then compound 2.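

In this assay, going by these compounds alone, the first single-place step is a number 82.2 percentage points lower from compound 2 to compound 4 (beyond the scatter), with 2,5-dimethylphenyl in place of 2,3-dimethylphenyl on an amine nitrogen in a ring. The two compounds have the same atoms, joined differently, so the read-out at this position depends strongly on how the two methyl groups are arranged on the phenyl, not merely on which atoms are present. No measurement shown gives a reason for this step.

The compounds shown leave open how much each methyl group contributes, which an unsubstituted phenyl or a phenyl bearing a single methyl group on this nitrogen could separate. They also leave open whether the same change has a similar effect when a fluorophenyl replaces the phenyl elsewhere on the shared core.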